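The source may hold more compounds than are shown below. What is called first, only, known or untested is meant among the compounds shown, and "the series" means these compounds.

Working notes on the series in an ADME assay on L02 cells (Homo sapiens) for antiproliferative activity, read by MTT assay, with a stated time of 48 h; on this read-out higher numbers stand for weaker inhibition and lower numbers for stronger inhibition.

Compound 3 `Cc1ccc(Cl)cc1-n1nncc1CN1C(=O)C2(C(C#N)=C(N)Oc3c(N)cc4nc5ccccc5nc4c32)c2ccccc21` gives in this assay only a limit, > 50000 nM, not a number. Compound 1 `Cc1ccccc1-n1nncc1CN1C(=O)C2(C(C#N)=C(N)Oc3c(N)cc4nc5ccccc5nc4c32)c2ccccc21` likewise gives only a limit in this assay, > 50000 nM. Compound 2 `N#CC1=C(N)Oc2c(N)cc3nc4ccccc4nc3c2C12C(=O)N(Cc1cnnn1-c1ccc([N+](=O)[O-])cc1)c1ccccc12` also returns a limit in this assay, > 50000 nM. All three values sit at the same limit, (the limit of > 50000 nM in this assay, at which 3 of the 3 values shown sit), so the steps between them cannot be sized: a step that the two limits leave unreadable from compound 1 to compound 2, a step that the two limits leave unreadable from compound 1 to compound 3 and a step that the two limits leave unreadable from compound 2 to compound 3 are each unreadable in this assay. The three aryl groups on the triazole nitrogen, 2-methylphenyl, 4-nitrophenyl and 5-chloro-2-methylphenyl, thus leave no readable trace on cell growth inhibition here.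

Compound 4 `Cc1cc(C)c(-n2nncc2CN2C(=O)C3(C(C#N)=C(N)Oc4c(N)cc5nc6ccccc6nc5c43)c3ccccc32)c(C)c1` is not yet measured. It differs from compound 3 by 2,4,6-trimethylphenyl in place of 5-chloro-2-methylphenyl on an aromatic nitrogen. The change is again confined to the aryl group on the aromatic nitrogen, the same place where the three measured steps fall, and every one of those steps stayed at the limit. Among the compounds with values here, no measured step gives a direction, and nothing suggests that this substitution would pull the value down into the readable range.

Compound 4 is therefore expected to show a step that the limit leaves unreadable from compound 3 to compound 4 from compound 3, which means no readable change. Compound 4 is estimated at 80000 nM in this assay, with a range from 30000 nM to 200000 nM, most likely reported again only as a limit.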

Compound 4, half-maximal inhibitory concentration: > 50000 nM
Compound 4 ended at the assay's limit; the forecaster's own chance of this, stated with the estimate: 85%; the middle value lies beyond the limit too.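

Compound 4 sits at the same limit as compound 1, compound 2 and compound 3 in this assay, so no step between compound 4 and these compounds can be read: the limit of > 50000 nM in this assay, at which 4 of the 4 values shown sit.

The compounds shown leave open how far each lies past this limit and whether any aryl group on the aromatic nitrogen would give a readable value.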